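The compounds below may be only part of what the source reports. "The series", "measured", "known", "first", "only" and "open" are said of these compounds alone.

In a functional assay on NCI-H292 cells (Homo sapiens) for antiproliferative activity (a lower number here means a stronger inhibitor, a higher number a weaker inhibitor), compound 1 `O=C1N/C(=C\c2ccc(O)cc2)C(=O)N1c1ccc(I)cc1` gives 25500 nM and compound 2 `Cc1ccc(N2C(=O)N/C(=C\c3ccc(O)cc3)C2=O)cc1` gives 27900 nM; between them a 1.1-fold higher number from compound 1 to compound 2 (0.04 log units; within the scatter). Compound 3 `O=C1N/C(=C\c2ccc(O)cc2)C(=O)N1c1ccc(Br)cc1` gives 69900 nM in this assay, the highest of the three numbers: a 2.7-fold higher number from compound 1 to compound 3 (0.44 log units; beyond the scatter), and a 2.5-fold higher number from compound 2 to compound 3 (0.40 log units; beyond the scatter). Compound 4 `O=C(NCc1ccccc1)c1ccc(N2C(=O)N/C(=C\c3ccc(O)cc3)C2=O)cc1` differs from compound 3 by benzylcarbamoyl in place of bromo on an aromatic carbon. The measured steps that bear on this change are the two in which bromo at this aromatic carbon is exchanged for another group, and each of them is modest; both show a lower number once bromo is gone, but neither introduces anything of comparable size, with a ring, a hydrogen-bond donor and a hydrogen-bond acceptor, so they give only a weak guide. A modest downward step in this assay is therefore expected for compound 4, with wide uncertainty. For compound 4 the estimate is 30000 nM, in the range 10000 nM to 90000 nM. That estimate means a 2.3-fold lower number from compound 3 to compound 4 (0.37 log units; beyond the scatter), expected rather than known.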

Compound 4, half-maximal inhibitory concentration: > 200000 nM
Compound 4: only a limit was reported (the forecaster's own chance of this, stated with the estimate: 10%); at least 6.6-fold (0.82 log units) between middle value and limit.
By their numbers in this assay, from the lowest: compounds 1 and 2 (each within the scatter of the next); then compound 3. At a limit, above all of these: compound 4.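

Compound 4 is reported in this assay only as a limit, not as a number: the limit of > 200000 nM in this assay, at which 1 of the 4 values shown sits. Exchanges among iodo, methyl and bromo at this aromatic carbon, para to a large group, stay in a narrow span, whereas benzylcarbamoyl gives an at least 2.8-fold higher number from compound 3 to compound 4 (0.45 log units; beyond the scatter) and an at least 7.1-fold higher number from compound 2 to compound 4 (0.85 log units; beyond the scatter) and also an at least 7.8-fold higher number from compound 1 to compound 4 (0.89 log units; beyond the scatter). The position therefore does not respond to every replacement of bromo with a lower number: both earlier steps away from bromo went down, and this one goes up.

Which part of benzylcarbamoyl carries the loss, the carbamoyl or the benzyl ring, stays open; a carboxylic acid or methylcarbamoyl at this carbon would help separate them. As far as these compounds go, the true size of the loss also stays open, since these steps are bounded on one side only.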